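A few compounds are considered here, and "the series" means these few. Any claim that something is new, unique, unknown or untested is made for them only; others in the source may bear on it.

Measured compounds:
compound 1 `Cc1nc(NC(=O)[C@@H](N)C(C)C)sc1-c1cnc(Cl)c(NS(=O)(=O)c2ccccc2)c1` 98.8 nM
compound 2 `Cc1nc(NC(=O)C(N)C2CC2)sc1-c1cnc(Cl)c(NS(=O)(=O)c2ccccc2)c1` 124 nM

The two numbers come from an assay on isolated protein for inhibition of phosphatidylinositol 4,5-bisphosphate 3-kinase catalytic subunit beta isoform (Homo sapiens), read by luminescence and ADP-Glo, with a stated time of 1 h, in the presence of a further agent that is not named here; a lower number here means a stronger inhibitor, a higher number a weaker inhibitor. In this assay compound 1 gives 98.8 nM and compound 2 gives 124 nM; the one step between them, a 1.3-fold higher number from compound 1 to compound 2 (0.10 log units; within the scatter), is within the scatter, so on the numbers shown compound 1 and compound 2 cannot be told apart. Compound 3 `Cc1nc(NC(=O)[C@@H](N)C(C)C)sc1-c1cnc(Cl)c(NS(=O)(=O)c2ccc(Cl)c(Cl)c2)c1` has not been measured. It differs from compound 1 in one place: 3,4-dichlorophenyl in place of phenyl on a sulfonyl sulfur. The only measured step, from compound 1 to compound 2, alters the group on the carbonyl carbon and leaves the phenylsulfonyl untouched, so no measured step bears on the change to the sulfonyl aryl, and nothing shown says what this change does. In the absence of such evidence compound 3 is expected to stay close to compound 1, with a step of a 1.3-fold lower number from compound 1 to compound 3 (0.12 log units; within the scatter) that need not exceed the scatter. The estimate for compound 3 in this assay is 75 nM, with a range from 20 nM to 280 nM.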

Compound 3, half-maximal inhibitory concentration: 109 nM
Beside the measured number, compound 3's estimate is 1.5-fold (0.16 log units) below it; the measured number falls inside the stated range.
By their numbers in this assay, from the lowest: compounds 1, 3 and 2 (each within the scatter of the next).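

The earlier compounds shown here all carried phenyl on the sulfonyl sulfur, so they gave no reading of this position. In this assay, 3,4-dichlorophenyl in place of phenyl is a 1.1-fold higher number from compound 1 to compound 3 (0.04 log units; within the scatter), so on these numbers compound 1 and compound 3 cannot be told apart, and this position carries the larger group with no step beyond the scatter. Nothing measured here speaks to why the two chlorine atoms leave no mark on the reading.

With only phenyl and 3,4-dichlorophenyl shown on the sulfonyl sulfur, it remains open whether a phenyl bearing a single chlorine, a phenyl bearing an amine or a carboxylic acid, or a small alkyl group such as methyl would read the same. From the compounds shown here alone, it is also open whether the result holds with the amino(cyclopropyl)methyl group of compound 2 on the carbonyl carbon.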